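Aryl ether to biaryl on the amide-bearing ring

The compounds below may be only part of what the source reports. "The series", "measured", "known", "first", "only" and "open" are said of these compounds alone.

Compound 1 `COc1cccc(C(=O)Nc2cccc(C(=O)O)c2)c1`, compound 2 `CCOc1cccc(C(=O)Nc2cccc(C(=O)O)c2)c1` and compound 3 `Cc1cccc(COc2cccc(C(=O)Nc3cccc(C(=O)O)c3)c2)c1` share one core and differ only in the group carried on the ether oxygen. In an assay on isolated protein for agonist activity at Bile acid receptor (Homo sapiens), read by TR-FRET, with a stated time of 3 h, in the absence of a further agent (on this read-out lower numbers stand for an effect already at smaller amounts and higher numbers for an effect only at larger amounts of compound), compound 1 gives 1040 nM, compound 2 gives 2350 nM and compound 3 gives 1860 nM. Compound 3 stands second highest of the three numbers; compound 2 is its nearest neighbour, within the scatter, and compound 1 lies furthest, also within the scatter. The measured steps are a 2.3-fold higher number from compound 1 to compound 2 (0.35 log units; beyond the scatter), a 1.8-fold higher number from compound 1 to compound 3 (0.25 log units; within the scatter) and a 1.3-fold lower number from compound 2 to compound 3 (0.10 log units; within the scatter); only the first goes beyond the scatter, and all three vary the group on the oxygen while keeping the ether itself.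

Compound 4 `Cc1ccccc1-c1cccc(C(=O)Nc2cccc(C(=O)O)c2)c1` goes further: 2-methylphenyl in place of (3-methylbenzyl)oxy on an aromatic carbon. The whole (3-methylbenzyl)oxy group leaves and a 2-methylphenyl sits directly on the aromatic carbon, meta to a large group. Among the compounds with values here, no measured step covers loss of the oxygen, so the three steps bear on it only indirectly, by showing that variation at this position has moved this assay little across the series. A small step is therefore expected, a 1.1-fold higher number from compound 3 to compound 4 (0.03 log units; within the scatter), with no direction beyond the scatter. Compound 4 is estimated at 2000 nM, with a range from 600 nM to 7000 nM.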

Compound 4, half-maximal effective concentration: 68 nM
Estimate against measurement, compound 4: 29-fold (1.47 log units) above; measured number below the stated range.
By their numbers in this assay, from the lowest: compound 4; then compounds 1, 3 and 2 (each within the scatter of the next, the first and the last beyond it).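

In this assay, setting 2-methylphenyl directly on the aromatic carbon gives a large drop against each ether: a 27-fold lower number from compound 3 to compound 4 (1.44 log units; beyond the scatter), a 35-fold lower number from compound 2 to compound 4 (1.54 log units; beyond the scatter) and a 15-fold lower number from compound 1 to compound 4 (1.18 log units; beyond the scatter). This position is therefore far from indifferent to change, since the largest step among the ethers is only a 2.3-fold higher number from compound 1 to compound 2 (0.35 log units; beyond the scatter), and the series responds much more strongly to the exchange of the whole ether for the directly attached aryl group than to any variation shown on the oxygen. Nothing available explains the size of this drop.

The change from compound 3 to compound 4 removes the oxygen and the saturated chain carbon and also moves the methyl group on the aromatic ring, so the compounds shown do not assign the drop to any one of these differences. Open questions are how an unsubstituted phenyl or a 3-methylphenyl on the same aromatic carbon would compare with the 2-methylphenyl, and whether a phenoxy or anilino group would keep the low number of compound 4.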